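Dropping the methyl: cytotoxicity expected to stay low

The source may report more compounds than this note shows. Statements on the series, on what has been measured and on what is new or still open speak of the compounds shown alone.

Compound 1 `Nc1ccc(-c2ccc3ncc(-c4noc(C(F)(F)F)n4)cc3c2)cn1` gives > 2500 nM in a functional assay on RD cells (Homo sapiens) for inhibition, read by luminescence and ATP content, with a stated time of 72 h (on this read-out higher numbers stand for lower toxicity in this test and lower numbers for higher toxicity in this test), a limit of that test.
Compound 2 `Cc1ccc(-c2ccc3ncc(-c4noc(C(F)(F)F)n4)cc3c2)cc1` gives > 22200 nM in this assay, again a limit.

Both values shown are limits, so the step from compound 1 to compound 2, a step that the two limits leave unreadable from compound 1 to compound 2, cannot be read, because the limit of > 22200 nM in this assay, at which 1 of the 2 values shown sits, and the limit of > 2500 nM in this assay, at which 1 of the 2 values shown sits, hold one value each. Going by the values given here, compound 2 therefore stands at a limit, with the one further value shown also a limit; nothing places it in order against compound 1.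

Compound 3 `FC(F)(F)c1nc(-c2cnc3ccc(-c4ccccc4)cc3c2)no1` differs from compound 2 by hydrogen in place of methyl on an aromatic carbon. Among the compounds with values here, no measured step of readable size bears on this change; the only step recorded is unreadable. The expectation is thus that compound 3 remains at low toxicity, with the estimated step that the limit leaves unreadable from compound 2 to compound 3 not beyond the scatter. Compound 3 is estimated at 25000 nM in this assay, within 8000 nM to 70000 nM, most likely again reported only as a limit.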

Compound 3, half-maximal cytotoxic concentration: > 22200 nM
Compound 3: only a limit was reported (the forecaster's own chance of this, stated with the estimate: 75%); the middle value is on the limit's open side.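

No new step can be read: compound 1, compound 2 and compound 3 all stand at limits, leaving the sizes of the changes among them unreadable. The compounds shown leave open whether either the methyl or the 6-aminopyridin-3-yl group alters the read-out in this assay at all.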